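This account rests on a few compounds, and the source may have more. Where it says the series, first, only, none or still open, it means among the compounds named here.

Compound 1 `CCN(CCNC(=O)c1cc(Cl)c(N)cc1OC)Cc1ccccn1` belongs to a small set of benzamides whose shared core carries an amide-linked chain ending in an amine nitrogen. Among the measured compounds shown here, in a functional assay on the whole organism with Rattus norvegicus as the target (on this read-out higher numbers stand for an effect only at larger amounts of compound and lower numbers for an effect already at smaller amounts), compound 1 gives 30 mg/kg, the highest of the two numbers measured so far. For the measured compounds named here, its nearest neighbour is compound 2 `CCN(CCNC(=O)c1cc(Cl)c(N)cc1OC)Cc1ccccc1OC`, which in this assay gives 10 mg/kg; the one step between them, a 3.0-fold lower number from compound 1 to compound 2 (0.48 log units; beyond the scatter), came from replacing pyridin-2-yl with 2-methoxyphenyl on a saturated chain carbon bound to an amine nitrogen.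

Compound 3 `CCN(CCNC(=O)c1cc(Cl)c(N)cc1OC)Cc1ccc(Cl)cc1Cl` has not yet been measured. It differs from compound 1 at the same place: 2,4-dichlorophenyl in place of pyridin-2-yl on a saturated chain carbon bound to an amine nitrogen. Going by the values given here, the one measured step that bears on this, a 3.0-fold lower number from compound 1 to compound 2 (0.48 log units; beyond the scatter), shows that exchanging the pyridin-2-yl for a six-membered aromatic ring of carbon only gave a lower number, and a modest step of a similar kind is therefore expected here, though the 2,4-dichlorophenyl is a different ring than the 2-methoxyphenyl and no step directly tests it. In this assay compound 3 is expected to give 12 mg/kg, within a range of 4 mg/kg to 40 mg/kg, which would mean an estimated step of a 2.5-fold lower number from compound 1 to compound 3 (0.40 log units; beyond the scatter).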

Compound 3, dose for half-maximal effect: 10 mg/kg
Beside the measured number, compound 3's estimate is 1.2-fold (0.08 log units) above it; the measured number falls inside the stated range.
By their numbers in this assay, from the lowest: compounds 2 and 3 (each within the scatter of the next); then compound 1.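

In this assay, 2,4-dichlorophenyl in place of pyridin-2-yl on a saturated chain carbon bound to an amine nitrogen gives a 3.0-fold lower number from compound 1 to compound 3 (0.48 log units; beyond the scatter), so a second ring of carbon only, bearing chlorine rather than a methoxy group, also stands apart from the pyridin-2-yl compound. Exchanging one of these carbon-only rings for the other gives no change at the digits printed from compound 2 to compound 3 (within the scatter), so the 2-methoxyphenyl and 2,4-dichlorophenyl groups are not told apart on this read-out, and among these three compounds, with none going against it, only the ring with a hetero atom stands apart, although that pattern rests on compound 1 alone. No measurement beyond these numbers accounts for either step.

The compounds shown leave open whether a plain phenyl ring, with neither chlorine nor a methoxy group, would fall with compound 2 and compound 3 or with compound 1. They also leave open whether the pyridin-2-yl result extends to a pyridin-3-yl ring, and what a longer chain carrying the ring would do at this place.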